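The source may hold more compounds than are shown below. What is called first, only, known or untested is meant among the compounds shown, and "the series" means these compounds.

Working notes on the series. In a functional assay on MCF7 cells (Homo sapiens) for inhibition, read by radiometric assay and XTT assay (a higher number here means a weaker inhibitor, a lower number a stronger inhibitor), compound 1 (`CCCCCCCC[C@@]1(C)SC(=O)C=C1OC`) gives 16.4 ug/mL and compound 2 (`CCCCCCCC[C@@]1(C)SC(=O)C=C1OCC(=O)O`) gives 50.3 ug/mL while compound 3 (`CCCCCCCC[C@@]1(C)SC(=O)C=C1OC(=O)CC`) gives 26.8 ug/mL on the same read-out. Compound 3 falls inside the span of the other two. The gaps a 1.6-fold higher number from compound 1 to compound 3 (0.21 log units; within the scatter) and a 1.9-fold lower number from compound 2 to compound 3 (0.27 log units; within the scatter) both stay within the scatter, so compound 3 is not separated from either neighbour.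

Next is compound 4 (`CCCCCCCC[C@@]1(C)SC(=O)C=C1OC(=O)OCC`), which carries ethoxy in place of ethyl on a carbonyl carbon and otherwise keeps the core and chain of compound 3. Within the data shown here, no measured step makes this exact change. The closest evidence is the pair of changes on the same oxygen, and both of those stayed within the scatter as shown above. Among the measured compounds shown here, the only step beyond the scatter is a 3.1-fold higher number from compound 1 to compound 2 (0.49 log units; beyond the scatter) and it is modest. It brings in carboxy, which compound 4 lacks, so it bears little on this change.

The expected outcome is a 1.1-fold lower number from compound 3 to compound 4 (0.03 log units; within the scatter) in this assay with no step beyond the scatter anticipated. For compound 4 the estimated value is 25 ug/mL with an expected range from 13 ug/mL to 48 ug/mL for a single measurement.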

Compound 4, half-maximal inhibitory concentration: 15.1 ug/mL
Compound 4: middle estimate off by 1.7-fold (0.22 log units), on the high side; the range from low to high includes it.
By their numbers in this assay, from the lowest: compounds 4, 1, 3 and 2 (each within the scatter of the next, the first and the last beyond it).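

Exchanging ethyl for ethoxy on a carbonyl carbon, which turns propanoyl into ethoxycarbonyl, gives a 1.8-fold lower number from compound 3 to compound 4 (0.25 log units; within the scatter) in this assay, so this change is not separated from the group it replaces. Ethoxycarbonyl in place of methyl on the same oxygen gives a 1.1-fold lower number from compound 1 to compound 4 (0.04 log units; within the scatter), which leaves methyl, propanoyl and ethoxycarbonyl within the scatter of one another on this oxygen across compound 1, compound 3 and compound 4. Ethoxycarbonyl in place of carboxymethyl gives a 3.3-fold lower number from compound 2 to compound 4 (0.52 log units; beyond the scatter), a modest step that adds a second separation from compound 2 alongside a 3.1-fold higher number from compound 1 to compound 2 (0.49 log units; beyond the scatter), although compound 3 goes against a clean split of compound 2 from the rest, as a 1.9-fold lower number from compound 2 to compound 3 (0.27 log units; within the scatter) stays within the scatter.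

No measurement on hand accounts for any of these steps. Still open, from the compounds shown here alone, is whether an amine in place of ethoxy on the carbonyl carbon, or a longer chain than ethoxy there, would move the number beyond the scatter from compound 4 in either direction.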